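This account rests on a few compounds, and the source may have more. Where it says the series, first, only, none or still open, it means among the compounds named here.

Measured so far in an assay on HEK293 cells for binding affinity to 5-hydroxytryptamine receptor 7 (Homo sapiens), read by radioligand binding, tested at 1 uM; a higher number here means more inhibition at the concentration tested (going by the name of the read-out), a lower number less inhibition:

- compound 1 `CN1CCCN(CCn2ccc3ccc(C(F)(F)F)cc32)CC1`: 89%
- compound 2 `CC(C)c1ccc2ccn(CCN3CCCN(C)CC3)c2c1`: 72%
- compound 3 `CC(C)CN1CCCN(CCn2ccc3ccc(Br)cc32)CC1`: 95%

Compound 3 stands highest of the three numbers in this assay. Compound 1 sits within the scatter of it, while compound 2 sits beyond the scatter below it. Compound 4 `Brc1ccc2ccn(CCN3CCCN(C4CCCCC4)CC3)c2c1` has not yet been measured. It differs from compound 3 in one place: cyclohexyl in place of isobutyl on an amine nitrogen in a ring.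

Within the data shown here, only one step between compounds that differ in a single place has been measured, a number 17 percentage points lower from compound 1 to compound 2 (beyond the scatter), and that step concerns the group on the aromatic carbon, not the amine nitrogen in the seven-membered ring. It therefore does not bear directly on the change from compound 3 to compound 4. Compound 1 and compound 3 differ in two places at once, so their values show only that both lie high, with no separate reading of the group on the ring nitrogen. Among the measured compounds shown here, no measured step speaks to an exchange of one alkyl group for another on that nitrogen. Given that compound 3 gives 95% in this assay with an isobutyl group already in that place, a step within the scatter, or at most a modest decrease, is expected. Compound 4 is estimated to give 88% in this assay, between 68% and 99%. That estimate means an expected step of a number 7 percentage points lower from compound 3 to compound 4 (within the scatter).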

Compound 4, a percentage reported as inhibition, at one concentration (the size of the read-out at that concentration, not a potency): 96%
For compound 4 the middle estimate is 8 percentage points below the measured one; measured number inside the range.
By their numbers in this assay, from the lowest: compound 2; then compounds 1, 3 and 4 (each within the scatter of the next).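

In this assay, among these compounds, the first measured exchange on the amine nitrogen in the seven-membered ring gives a number 1 percentage points higher from compound 3 to compound 4 (within the scatter), so this read-out does not separate cyclohexyl from isobutyl at this position. The entering group has more heavy atoms and carries a six-membered ring of carbon only, whereas the leaving group has no ring, and this change in the substituent leaves the number within the scatter, something that the comparison of compound 1 with compound 3, which differ in two places at once, could not show. No measurement offered here accounts for this outcome, and the step itself gives no reason for it.

What the compounds shown leave open is whether the same holds for groups of another kind on this nitrogen, such as a benzyl group, an acetyl group or a hydroxyethyl chain, or for the bare nitrogen carrying only hydrogen. Also open, from the compounds shown here alone, is whether compound 3 and compound 4 differ in potency, as a reading at one concentration gives the size of the inhibition at that concentration and no more.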